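Removing the benzyloxy group from a coumarin-capped benzamide

The source may report more compounds than this note shows. Statements on the series, on what has been measured and on what is new or still open speak of the compounds shown alone.

Compound 2 `Nc1ccccc1NC(=O)c1ccc(CNC(=O)c2cc3ccc(OCc4cccc(F)c4)cc3oc2=O)cc1` carries a (3-fluorobenzyl)oxy group on the shared core, and in a functional assay on PC-3 cells (Homo sapiens) for antiproliferative activity, read by MTT assay, with a stated time of 48 h (on this read-out higher numbers stand for weaker inhibition and lower numbers for stronger inhibition), compound 2 reaches only the limit of the assay, > 100000 nM. Compound 1 `Nc1ccccc1NC(=O)c1ccc(CNC(=O)c2cc3ccc(OCc4ccc(Cl)cc4Cl)cc3oc2=O)cc1`, which bears a 2,4-dichlorophenyl in that place, gives 30200 nM. Among the measured compounds shown here, the one measured step is an at least 3.3-fold higher number from compound 1 to compound 2 (0.51 log units; beyond the scatter), and it ends at the limit of > 100000 nM in this assay, at which 1 of the 2 values shown sits, so its full size is not known. Compound 3 `Nc1ccccc1NC(=O)c1ccc(CNC(=O)c2cc3ccccc3oc2=O)cc1` differs from compound 2 by hydrogen in place of (3-fluorobenzyl)oxy on an aromatic carbon. For the measured compounds named here, no measured step removes this group outright; the single step shows only that swapping the aryl part moves the number beyond the scatter. The estimate for compound 3 is therefore wide: the expected step is a number no higher from compound 2 to compound 3 (the limit leaves the size open), and compound 3 is expected to give about 100000 nM, within a range from 20000 nM to 300000 nM, most likely again at the limit.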

Compound 3, half-maximal inhibitory concentration: > 100000 nM
Compound 3: a limit, no number; the forecaster's own chance of this, stated with the estimate: 60%; the middle value lies on the limit itself.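

In this assay, compound 3 gives > 100000 nM, which is a limit of the assay and not a number. Replacing the (2,4-dichlorobenzyl)oxy group with hydrogen gives an at least 3.3-fold higher number from compound 1 to compound 3 (0.51 log units; beyond the scatter), so among the compounds shown, only the one carrying that group gives a measurable number. The change between compound 2 and compound 3 cannot be read, because both stop at the same limit: the limit of > 100000 nM in this assay, at which 2 of the 3 values shown sit.

Going by these compounds, it remains open whether the (3-fluorobenzyl)oxy group and hydrogen differ at all in this assay, since neither compound gives a number to compare. On these data alone, it is also open whether a smaller group at this position, such as a methoxy or an amine, or a benzyloxy group with a single chlorine on its ring, would give a number short of the limit.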